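Swapping an aminopropyl ketone for a thiophene ketone

The source may hold more compounds than are shown below. What is called first, only, known or untested is meant among the compounds shown, and "the series" means these compounds.

Compound 1 `COc1ccccc1C(=O)c1ccn(-c2ccc3c(c2)B(O)OC3)c1`: in an ADME assay on L929 cells (Mus musculus) for cytotoxicity, read by resazurin assay, with a stated time of 72 h (a higher number here means a weaker inhibitor, a lower number a stronger inhibitor), compound 1 gives > 10 ug/mL, which is a limit of the assay rather than a number.
Compound 2 `CCCC(=O)c1ccn(-c2ccc3c(c2)B(O)OC3)c1`: in this assay compound 2 gives > 10 ug/mL, again only a limit.
Compound 3 `NCCCC(=O)c1ccn(-c2ccc3c(c2)B(O)OC3)c1`: in this assay compound 3 gives > 10 ug/mL, also a limit.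

Compound 3 therefore stands where every measured compound stands: at the limit of > 10 ug/mL in this assay, at which 3 of the 3 values shown sit. None of the three shows a readable number, so none can be called more or less toxic than another.

Compound 4 `Cc1ccsc1C(=O)c1ccn(-c2ccc3c(c2)B(O)OC3)c1` differs from compound 3 at the carbonyl carbon: 3-methylthiophen-2-yl in place of 3-aminopropyl on a carbonyl carbon. The measured steps that touch the same carbonyl carbon are a step that the two limits leave unreadable from compound 1 to compound 3, a step that the two limits leave unreadable from compound 2 to compound 3 and a step that the two limits leave unreadable from compound 1 to compound 2; all three run between limits and give no size. Compound 1, which also carries an aromatic ring on that carbonyl carbon, sits at the same limit as compound 3.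

Compound 4 is therefore expected to sit at the limit as well, with a step that the limit leaves unreadable from compound 3 to compound 4 expected rather than anything beyond the scatter. For compound 4 the estimate is 15 ug/mL, within a range from 5 ug/mL to 50 ug/mL.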

Compound 4, half-maximal inhibitory concentration: > 10 ug/mL
Compound 4: a limit, no number; the forecaster's own chance of this, stated with the estimate: 80%; the middle value does not contradict the limit.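

No step can be read between compound 4 and compound 1, compound 2 or compound 3, because all four sit at the same limit: the limit of > 10 ug/mL in this assay, at which 4 of the 4 values shown sit.

The compounds shown leave open how toxic each one actually is in this assay and whether the group on the carbonyl carbon makes any difference to that.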